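Compound 2 to compound 3: replacing the 1,2-dihydroxyethyl group

The compounds below may be only part of what the source reports. "The series", "measured", "known", "first", "only" and "open" are said of these compounds alone.

Values from a physicochemical assay for solubility, read by HPLC, with a stated time of 20 h, at pH 1 (on this read-out higher numbers stand for higher solubility and lower numbers for lower solubility), follow

- Compound 1 `CC(C)(O)CNC(=O)C[C@H]1CC[C@H](c2ccc(C(=O)Nc3nnc(Cc4ccccc4)s3)cc2)CC1` gives < 2000 nM (a limit)
- Compound 2 `O=C(C[C@H]1CC[C@H](c2ccc(C(=O)Nc3nnc(Cc4ccccc4)s3)cc2)CC1)NCC(O)CO` gives < 2000 nM (a limit)

Compound 2 stands only at a limit (< 2000 nM). Among the compounds with values here, the sole measured step is a step that the two limits leave unreadable from compound 1 to compound 2 and offers no size to carry forward. Compound 3 `CN(C)CCNC(=O)C[C@H]1CC[C@H](c2ccc(C(=O)Nc3nnc(Cc4ccccc4)s3)cc2)CC1` has (dimethylamino)methyl in place of 1,2-dihydroxyethyl on a saturated chain carbon bound to an amide-type nitrogen. On this structural change alone, an upward move in this assay is expected, with an estimated size of an at least 10-fold higher number from compound 2 to compound 3 (1.00 log units; beyond the scatter) (a loose judgement). For compound 3 the expected value is 20000 nM (estimated range 2000 nM to 200000 nM).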

Compound 3, solubility: 6000 nM
Estimate against measurement, compound 3: 3.3-fold (0.52 log units) above; low and high end bracket the measured number.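

In this assay, within the data shown here, (dimethylamino)methyl on a saturated chain carbon bound to an amide-type nitrogen gives the first number here that is not a limit, with an at least 3.0-fold higher number from compound 2 to compound 3 (0.47 log units; beyond the scatter) and an at least 3.0-fold higher number from compound 1 to compound 3 (0.47 log units; beyond the scatter). Both sizes are minimum sizes, and the real steps may be larger: the limit of < 2000 nM in this assay, at which 2 of the 3 values shown sit. The two hydroxylated compounds cannot be ordered, as the step between them cannot be read.

The compounds shown leave open whether a primary amine, a morpholine or a longer chain carrying the dimethylamino group would read the same way at this place.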